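This account rests on a few compounds, and the source may have more. Where it says the series, first, only, none or still open, it means among the compounds named here.

Compound 1 `CCCCOc1ccc(C(=O)NNC(=O)c2ccccc2NS(=O)(=O)c2cnc(O)nc2O)cc1`: 6830 nM
Compound 2 `Cc1ccccc1C(=O)NNC(=O)c1ccccc1NS(=O)(=O)c1cnc(O)nc1O`: 5570 nM

In a functional assay on MDA-MB-231 cells (Homo sapiens) for antiproliferative activity, read by MTT assay, with a stated time of 24 h (a higher number here means a weaker inhibitor, a lower number a stronger inhibitor), compound 2 gives 5570 nM and stands level with compound 1 within the scatter. Compound 3 `O=C(NNC(=O)c1ccccc1NS(=O)(=O)c1cnc(O)nc1O)c1ccccc1F` is not yet measured and differs from compound 2 in one place: fluoro in place of methyl on an aromatic carbon with fluoro in place of methyl on an aromatic carbon, ortho to a large group. Among the measured compounds shown here, only one measured step bears on this: a 1.2-fold lower number from compound 1 to compound 2 (0.09 log units; within the scatter) when the whole group on that carbonyl carbon was exchanged. The smaller exchange here gives no reason to expect more, so the expected step of a 1.0-fold higher number from compound 2 to compound 3 (0.02 log units; within the scatter) stays within the scatter. Compound 3 is estimated at 5800 nM with 2600 nM to 12000 nM as the expected range.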

Compound 3, half-maximal inhibitory concentration: > 20000 nM
Compound 3: no number, only a limit; the forecaster's own chance of this, stated with the estimate: 5%; middle value at least 3.4-fold (0.53 log units) away from the limit.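

In this assay compound 3 gives only a limit of the assay, not a number: the limit of > 20000 nM in this assay, at which 1 of the 3 values shown sits. Fluoro in place of methyl on this aromatic carbon, ortho to a large group, gives an at least 3.5-fold higher number from compound 2 to compound 3 (0.55 log units; beyond the scatter), so exchanging one heavy atom here can matter. The 2-fluorophenyl group in place of 4-butoxyphenyl gives an at least 2.9-fold higher number from compound 1 to compound 3 (0.46 log units; beyond the scatter), whereas the 2-methylphenyl group gave a 1.2-fold lower number from compound 1 to compound 2 (0.09 log units; within the scatter), so the outcome depends on the group entering and not only on how much is exchanged.

The compounds shown leave open whether chloro, hydroxy or methoxy at this place would behave like methyl or like fluoro. Going by these compounds, the full size of the step also stays unknown.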